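Notes on a bromo to chloro swap in the series

The source may report more compounds than this note shows. Statements on the series, on what has been measured and on what is new or still open speak of the compounds shown alone.

- compound 1 `C=C1CC(C(Br)c2ccccc2)OC1=O` gives 20300 nM in a functional assay on A-431 cells (Homo sapiens) for antiproliferative activity, read by sulforhodamine B assay, with a stated time of 72 h; on this read-out higher numbers stand for weaker inhibition and lower numbers for stronger inhibition
- compound 2 `C=C1CC(c2ccccc2)(C(Br)c2ccccc2)OC1=O` gives 4190 nM in this assay
- compound 3 `C=C1CC(c2ccccc2)(C(C)Br)OC1=O` gives 5240 nM in this assay

Compound 2 shares the low end of these numbers with compound 3, the two being separated by a 1.3-fold higher number from compound 2 to compound 3 (0.10 log units; within the scatter) only. Compound 1 stands apart, with a 4.8-fold lower number from compound 1 to compound 2 (0.69 log units; beyond the scatter) as the step beyond the scatter.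

The next entry is compound 4 `C=C1CC(c2ccccc2)(C(Cl)c2ccccc2)OC1=O`, which carries chloro in place of bromo on a saturated chain carbon bound to an aromatic carbon and a saturated ring carbon. Among the measured compounds shown here, no measured pair exchanges one halogen for another, so no step speaks to this change directly. The closest guide is compound 3, where the change of phenyl to methyl on the bromine-bearing chain carbon gave a 1.3-fold higher number from compound 2 to compound 3 (0.10 log units; within the scatter) as its step. The larger step, a 4.8-fold lower number from compound 1 to compound 2 (0.69 log units; beyond the scatter), arose on a saturated ring carbon and not at this place. A small change is therefore expected in this assay, perhaps towards a slightly higher number, and none beyond the scatter. The estimate amounts to a 1.4-fold higher number from compound 2 to compound 4 (0.16 log units; within the scatter) as the expected step. For compound 4 the expected value is 6000 nM, with an estimated range from 2500 nM to 14000 nM as the likely span.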

Compound 4, half-maximal inhibitory concentration: 2770 nM
Compound 4: middle estimate off by 2.2-fold (0.34 log units), on the high side, within the range that was stated.
By their numbers in this assay, from the lowest: compounds 4, 2 and 3 (each within the scatter of the next); then compound 1.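

Chloro in place of bromo on a saturated chain carbon bound to an aromatic carbon and a saturated ring carbon is the only halogen exchange in the series so far, and in this assay it gives a 1.5-fold lower number from compound 2 to compound 4 (0.18 log units; within the scatter) as its step. With phenyl on the saturated ring carbon, the read-out therefore does not separate bromo from chloro at this place, and either halogen leaves the number in the same range as compound 2. No measurement at hand accounts for this result or says how the two halogens act here.

From the compounds shown here alone, whether a halogen is needed on this carbon at all remains open, and fluoro, a hydroxyl or an amine at the same place would help to settle that. Also open, going by these compounds, is whether the exchange reads the same in the setting of compound 3, with methyl in place of phenyl on the chain carbon, or in that of compound 1, with hydrogen in place of phenyl on the saturated ring carbon.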